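The source may hold more compounds than are shown below. What is called first, only, known or untested is meant among the compounds shown, and "the series" means these compounds.

Measured so far:
Compound 1 `COc1ccc(-c2c(Br)c(=O)c3c(OC)cc(OC)cc3n2S(=O)(=O)c2ccc(OC)cc2)cc1`: in an ADME assay on BJ cells (Homo sapiens) for antiproliferative activity, with a stated time of 72 h (a higher number here means that more compound is needed for the effect, a lower number that less compound is needed), compound 1 gives 49700 nM.
Compound 2 `COc1ccc(-c2cc(=O)c3c(OC)cc(OC)cc3n2S(=O)(=O)c2ccc(F)cc2)cc1`: compound 2 gives only an assay limit, > 65500 nM.
Compound 3 `COC(=O)c1cc(=O)c2cc(NC(=O)Nc3ccc(C(F)(F)F)cc3[N+](=O)[O-])ccc2[nH]1`: compound 3 gives only an assay limit, > 51700 nM.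

Compound 3 thus stands not at a number but at the limit of > 51700 nM in this assay, at which 1 of the 3 values shown sits. Compound 2 likewise sits at the limit of > 65500 nM in this assay, at which 1 of the 3 values shown sits. Within the data shown here, the only number among the three, from compound 1, lies near those limits, so all three appear weak in this assay.

Compound 4 `COC(=O)c1cc(=O)c2cc(NC(=O)Nc3ccc(C(F)(F)F)cc3)ccc2[nH]1` differs from compound 3 by hydrogen in place of nitro on an aromatic carbon. Among the measured compounds shown here, no measured pair shows this change. Compound 4 is expected to remain weak, with an estimate of 60000 nM (range 25000 nM to 150000 nM), most likely reported again as a limit. This estimate means a step that the limit leaves unreadable from compound 3 to compound 4, nothing beyond the usual scatter.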

Compound 4, half-maximal effective concentration: > 12600 nM
Compound 4 ended at the assay's limit; the forecaster's own chance of this, stated with the estimate: 70%; the middle value does not contradict the limit.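

Among these compounds, compound 3 and compound 4 both give only assay limits, and no step between them can be read. The compounds shown leave open whether hydrogen in place of nitro changes the half-maximal effective concentration at all.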